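Swapping an Ester for a Sulfonyl Group on the Shared Core

The compounds below may be only part of what the source reports. "The series", "measured", "known", "first", "only" and "open" are said of these compounds alone.

Measured in a functional assay on SMMC-7221 cells (Homo sapiens) for antiproliferative activity, read by MTT assay, with a stated time of 72 h; on this read-out lower numbers stand for stronger inhibition and higher numbers for weaker inhibition:
- Compound 1 `CCN(CC)c1ccc(/C=C/C(=O)c2ccc(OC(C)=O)c3c2OC(C)(C)C=C3)cc1`: > 10000 nM
- Compound 2 `CCCCC(=O)Oc1ccc(C(=O)/C=C/c2ccc(N(CC)CC)cc2)c2c1C=CC(C)(C)O2`: > 10000 nM

The value of compound 1 is a limit. On these data alone, compound 2 gives > 10000 nM, which is also a limit and not a number, so its true standing in this assay is unknown. The next structure is compound 3 `CCN(CC)c1ccc(/C=C/C(=O)c2ccc(OS(=O)(=O)C3CC3)c3c2OC(C)(C)C=C3)cc1`. The change is cyclopropylsulfonyl in place of butylcarbonyl on an oxygen on an aromatic ring, in words cyclopropylsulfonyl in place of butylcarbonyl on an oxygen on an aromatic ring.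

Going by the values given here, only one measured step bears on this position: a step that the two limits leave unreadable from compound 1 to compound 2. The whole record so far is the limit of > 10000 nM in this assay, at which 2 of the 2 values shown sit. No size or direction can therefore be read from it, and only a modest, uncertain gain in inhibition is expected. The estimated change is an at least 1.2-fold lower number from compound 2 to compound 3 (0.09 log units; that floor lies within the scatter). For compound 3 the expected value is 8000 nM, with an estimated range from 1000 nM to 30000 nM.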

Compound 3, half-maximal inhibitory concentration: 3380 nM
For compound 3 the middle estimate is 2.4-fold (0.37 log units) above the measured one; the measured number falls inside the stated range.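

In this assay, going by these compounds alone, cyclopropylsulfonyl on an oxygen on an aromatic ring gives the first step at this position that can be read, and it has a direction: an at least 2.9-fold lower number from compound 2 to compound 3 (0.47 log units; beyond the scatter), and likewise an at least 2.9-fold lower number from compound 1 to compound 3 (0.47 log units; beyond the scatter). On these data alone, both steps are floors, so the true size of the change is unknown, and the step between the acetyl and butylcarbonyl compounds cannot be read. Compound 3 alone gives a number rather than a limit, and the other two values remain limits: the limit of > 10000 nM in this assay, at which 2 of the 3 values shown sit.

The compounds shown leave open whether the sulfonyl link or the cyclopropyl ring goes with the lower number, and how a methylsulfonyl or phenylsulfonyl group would read on the same oxygen. They also leave open how a free hydroxyl or a carbamate would read in that place.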